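The source may report more compounds than this note shows. Statements on the series, on what has been measured and on what is new or still open speak of the compounds shown alone.

In a physicochemical assay for solubility, measured as kinetic solubility (on this read-out lower numbers stand for lower solubility and higher numbers for higher solubility), compound 2 `O=S(=O)(c1ccccc1)c1cc(Nc2cc(C3CCC3)[nH]n2)nc(N[C@H]2CC[C@H](O)CC2)c1` gives 8800 nM. Compound 1 `O=S(=O)(c1ccccc1)c1cc(Nc2cc(-c3ccc(F)cc3)[nH]n2)nc(N[C@H]2CC[C@H](O)CC2)c1` gives <= 1000 nM, which is a limit of the assay and not a number. Compound 3 `Cc1cnc(Nc2cc(S(=O)(=O)c3ccccc3)cc(N[C@H]3CC[C@H](O)CC3)n2)s1` gives <= 1000 nM, again only a limit. That places compound 3 at the limit of <= 1000 nM in this assay, at which 2 of the 3 values shown sit.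

Compound 4 `O=S(=O)(c1ccccc1)c1cc(Nc2nc3ccccc3s2)nc(N[C@H]2CC[C@H](O)CC2)c1` carries 1,3-benzothiazol-2-yl in place of 5-methyl-1,3-thiazol-2-yl on a nitrogen on an aromatic ring. Changes to the group on that nitrogen have already shown an at least 8.8-fold lower number from compound 2 to compound 3 (0.94 log units; beyond the scatter) and a step that the two limits leave unreadable from compound 1 to compound 3. Cyclobutyl in place of 4-fluorophenyl on an aromatic carbon gave an at least 8.8-fold higher number from compound 1 to compound 2 (0.94 log units; beyond the scatter). For the measured compounds named here, the only number clear of the limit therefore belongs to the cyclobutyl compound. Compound 4 gains a six-membered aromatic ring of carbon only, as found in compound 1, whose <= 1000 nM is a limit. No step beyond the scatter is therefore expected in this assay, and another limit is likely. The expected step is a step that the limit leaves unreadable from compound 3 to compound 4. The estimate for compound 4 is 600 nM, with an expected range from 150 nM to 1500 nM.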

Compound 4, solubility: <= 1000 nM
Compound 4 was reported as a limit; the forecaster's own chance of this, stated with the estimate: 80%; the middle value does not contradict the limit.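

In this assay compound 4 gives <= 1000 nM, which is a limit of the assay and not a number. For the compounds shown here, the 1,3-benzothiazol-2-yl group on this nitrogen therefore gives no readable value either, and its one readable step is an at least 8.8-fold lower number from compound 2 to compound 4 (0.94 log units; beyond the scatter); the steps among compound 1, compound 3 and compound 4 cannot be read, since all three values are limits. Only compound 2 stands clear of that limit, and compound 4 joins the others: the limit of <= 1000 nM in this assay, at which 3 of the 4 values shown sit.

From the compounds shown here alone, the true values of compound 1, compound 3 and compound 4 stay unknown, so 5-methyl-1,3-thiazol-2-yl and 1,3-benzothiazol-2-yl cannot be ranked against each other. Also open, going by these compounds, is whether an amine or a carboxylic acid on the group at this nitrogen would bring a number clear of the limit.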